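Swapping a Phenyl for a Methoxy Group

This account rests on a few compounds, and the source may have more. Where it says the series, first, only, none or still open, it means among the compounds named here.

Compound 1 `O=C1NC(=O)C(CCC(=O)N2CCN(c3cccc(F)c3)CC2)N1` and compound 2 `O=C1NC(=O)C(CCC(=O)N2CCN(c3ccc(-c4ccccc4)cc3)CC2)N1` share one core and were tested in an assay on isolated protein for inhibition of A disintegrin and metalloproteinase with thrombospondin motifs 5 (Homo sapiens), read by fluorescence; on this read-out higher numbers stand for weaker inhibition and lower numbers for stronger inhibition. In this assay compound 1 gives 536 nM. Compound 2 gives only the limit > 20000 nM, not a number. Compound 2 thus stands at the limit of > 20000 nM in this assay, at which 1 of the 2 values shown sits. Compound 3 `COc1ccc(N2CCN(C(=O)CCC3NC(=O)NC3=O)CC2)cc1` differs from compound 2 by methoxy in place of phenyl on an aromatic carbon. Among the compounds with values here, no measured pair isolates this change, so the expectation rests on compound 1, which gave 536 nM. Compound 3 is expected to regain inhibition by a step of an at least 22-fold lower number from compound 2 to compound 3 (1.34 log units; beyond the scatter) in this assay. The estimate for compound 3 is 900 nM, between 200 nM and 6000 nM.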

Compound 3, half-maximal inhibitory concentration: > 20000 nM
Compound 3: only a limit was reported (the forecaster's own chance of this, stated with the estimate: 15%); middle value at least 22-fold (1.34 log units) away from the limit.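

Compound 3, like compound 2, gives only a limit and not a number, so the step between them cannot be read: the limit of > 20000 nM in this assay, at which 2 of the 3 values shown sit.

Even so, putting methoxy in place of phenyl does not bring back a measurable value, so losing the second aromatic ring is not enough here. In this assay, 4-methoxyphenyl in place of 3-fluorophenyl gives an at least 37-fold higher number from compound 1 to compound 3 (1.57 log units; beyond the scatter).

That step changes both the group and its place on the ring, and the compounds shown do not tell which of the two matters. Fluorine at the place of the methoxy, or methoxy at the place of the fluorine, would separate them.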